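A few compounds are considered here, and "the series" means these few. Any claim that something is new, unique, unknown or untested is made for them only; others in the source may bear on it.

Compound 1 `O=C1c2c[n+]([O-])c3ccccc3c2C(=O)c2c1c1ccccc1n2Cc1cn(CC(O)CO)nn1`: 760 nM
Compound 2 `CN1CCN(CCCCn2c3c(c4ccccc42)C(=O)c2c[n+]([O-])c4ccccc4c2C3=O)CC1`: 100 nM

In a toxicity assay on HEK-293T cells (Homo sapiens) for cytotoxicity, read by MTT assay, with a stated time of 72 h (on this read-out lower numbers stand for stronger inhibition and higher numbers for weaker inhibition), compound 1 gives 760 nM, the higher of the two numbers. Compound 3 `O=C1c2c[n+]([O-])c3ccccc3c2C(=O)c2c1c1ccccc1n2Cc1cn([C@@H]2O[C@H](CO)[C@@H](O)[C@H](O)[C@H]2O)nn1` keeps the core of compound 1 and differs in one group on an aromatic nitrogen: 3,4,5-trihydroxy-6-(hydroxymethyl)oxan-2-yl in place of 2,3-dihydroxypropyl on an aromatic nitrogen. Among the measured compounds shown here, only one measured step exists, a 7.6-fold lower number from compound 1 to compound 2 (0.88 log units; beyond the scatter), and it exchanges the whole side group, so it bears only loosely on this change. For the measured compounds named here, no measured step tests this exchange itself, so only a small move towards a higher number is expected in this assay. The expected step is a 1.3-fold higher number from compound 1 to compound 3 (0.12 log units; within the scatter). For compound 3 the estimate is 1000 nM, with an expected range of 350 nM to 3000 nM.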

Compound 3, half-maximal inhibitory concentration: 940 nM
Compound 3: the middle estimate sits 1.1-fold (0.03 log units) above what was measured; measured number inside the range.
By their numbers in this assay, from the lowest: compound 2; then compounds 1 and 3 (each within the scatter of the next).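

In this assay, 3,4,5-trihydroxy-6-(hydroxymethyl)oxan-2-yl in place of 2,3-dihydroxypropyl on an aromatic nitrogen gives a 1.2-fold higher number from compound 1 to compound 3 (0.09 log units; within the scatter) and so stays within the scatter. This is the first step shown that leaves the rest of the side group untouched, and at this position the six-membered non-aromatic ring and its 5 defined stereocentres bring no change beyond the scatter. No measurement at hand accounts for this result.

The compounds shown leave open what a carboxylic acid or a primary amine on this same aromatic nitrogen would give. They also do not tell whether the other stereoisomers of the entering group would read alike.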